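Amino Substitution Carried Over to a Second Core

The compounds below may be only part of what the source reports. "The series", "measured", "known", "first", "only" and "open" are said of these compounds alone.

Compound 1, `COc1ccc(-c2coc(=O)n2-c2cc(OC)c(OC)c(OC)c2)cc1`: 7.5 nM
Compound 2, `COc1ccc(-c2coc(=O)n2-c2cc(OC)c(OC)c(OC)c2)cc1N`: 2.5 nM
Compound 3, `COc1ccc(-c2oc(O)nc2-c2cc(OC)c(OC)c(OC)c2)cc1`: 20.1 nM

In a functional assay on PC-3 cells (Homo sapiens) for inhibition (a higher number here means a weaker inhibitor, a lower number a stronger inhibitor), compound 3 gives the highest number of the three measured compounds; compound 1 is lower by a margin beyond the scatter, and compound 2 is lower still. Compound 4, `COc1ccc(-c2oc(O)nc2-c2cc(OC)c(OC)c(OC)c2)cc1N`, differs from compound 3 only by amino in place of hydrogen on an aromatic carbon. Within the data shown here, the one measured step that bears on this change is the same substitution on the core of compound 1, which gave a 3.0-fold lower number from compound 1 to compound 2 (0.48 log units; beyond the scatter). On that basis a step of similar size and direction is expected from compound 3 to compound 4, namely a 3.0-fold lower number from compound 3 to compound 4 (0.48 log units; beyond the scatter). Compound 4 is therefore estimated at 6.7 nM in this assay, within a range of 3 nM to 15 nM.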

Compound 4, half-maximal inhibitory concentration: 2.1 nM
Compound 4: the middle estimate sits 3.2-fold (0.50 log units) above what was measured, and the stated range ends above it.
By their numbers in this assay, from the lowest: compounds 4 and 2 (each within the scatter of the next); then compound 1; then compound 3.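

In this assay, amino in place of hydrogen on the aromatic carbon ortho to a methoxy group again lowers the number on a second core, with a 9.6-fold lower number from compound 3 to compound 4 (0.98 log units; beyond the scatter). The direction of the change therefore holds on both cores, but its size depends on the core: the same change on two cores in this assay, a 3.0-fold lower number (0.48 log units; beyond the scatter) from compound 1 to compound 2 and a 9.6-fold lower number (0.98 log units; beyond the scatter) from compound 3 to compound 4, 3.2-fold (0.50 log units) apart, beyond the scatter of two such steps.

The compounds shown do not explain why the two steps differ in size. They also leave open whether a hydroxyl, a methylamino or an acetamido group on this same carbon would lower the number on both cores as amino does.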